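This account rests on a few compounds, and the source may have more. Where it says the series, first, only, none or still open, it means among the compounds named here.

Measured so far:
- compound 1, `CCCN(CCC)c1cc(C)nc2c(-c3ccc(Cl)cn3)c(C)nn12`: 88 nM
- compound 2, `CCCN(CCC)c1cc(C)nc2c(-c3ncc(O)cc3C)c(C)nn12`: 530 nM

Both compounds were tested in an assay on isolated protein for binding affinity to corticotropin-releasing factor receptor 1 (Homo sapiens); on this read-out higher numbers stand for weaker inhibition and lower numbers for stronger inhibition. Compound 1 gives 88 nM in this assay, and compound 2 gives 530 nM. Among the compounds with values here, compound 2 therefore stands at the weaker end of these two numbers; its only neighbour is compound 1, and the gap is described by the step of a 6.0-fold higher number from compound 1 to compound 2 (0.78 log units; beyond the scatter).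

The new compound 3, `CCCN(CCC)c1cc(C)nc2c(-c3ncc(C)cc3OC)c(C)nn12`, shares the whole core of compound 2 and differs only in the aromatic ring attached to it: 3-methoxy-5-methylpyridin-2-yl in place of 5-hydroxy-3-methylpyridin-2-yl on an aromatic carbon. Within the data shown here, the one measured step that bears on this position is a 6.0-fold higher number from compound 1 to compound 2 (0.78 log units; beyond the scatter), which shows that exchanging the group on this aromatic carbon can shift the number by a clearly noticeable amount. Among the measured compounds shown here, no measured pair covers the exact exchange from compound 2 to compound 3, so the direction rests on a single comparison. For the measured compounds named here, since the only change at this position so far moved the number up from compound 1 to compound 2, and compound 3 moves away from the hydroxy-bearing group again, a modest return toward the lower number is expected, roughly a 2.9-fold lower number from compound 2 to compound 3 (0.47 log units; beyond the scatter). For compound 3 the expected value is 180 nM, with a likely range from 50 nM to 600 nM.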

Compound 3, inhibition constant: 25 nM
Compound 3: middle estimate off by 7.2-fold (0.86 log units), on the high side, and the stated range ends above it.
By their numbers in this assay, from the lowest: compound 3; then compound 1; then compound 2.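

In this assay the exchange of 5-hydroxy-3-methylpyridin-2-yl for 3-methoxy-5-methylpyridin-2-yl gives a 21-fold lower number from compound 2 to compound 3 (1.33 log units; beyond the scatter) and so shows that this place on the shared core can move the number far downward, whereas the earlier pair showed only a rise. The new ring also goes beyond the earlier 5-chloropyridin-2-yl, with a 3.5-fold lower number from compound 1 to compound 3 (0.55 log units; beyond the scatter) so the fall from compound 2 is more than a return to the level of compound 1. The two group names show that two things change together, a hydroxy becoming a methoxy and the oxygen and methyl groups trading ring positions, and nothing at hand explains the size of the step.

Which of these two changes carries the step stays open: 5-methoxy-3-methylpyridin-2-yl would keep the methoxy but return the groups to the ring positions they hold in compound 2. As far as these compounds go, it is also open how the number in this assay would respond if the methoxy gave way to an ethoxy or an amine, or if the 5-methyl gave way to a chlorine.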